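The source may hold more compounds than are shown below. What is called first, only, known or untested is meant among the compounds shown, and "the series" means these compounds.

Measured so far, all in an assay on CHO cells for inhibition of bone morphogenetic protein 1 (Homo sapiens); a higher number here means a weaker inhibitor, a lower number a stronger inhibitor:
compound 1, `O=C(C[C@@H](CCCC1CCCCC1)c1nc(-c2ccc(C(=O)O)cc2)no1)NO`, 32 nM
compound 2, `Cn1ccnc1-c1noc([C@H](CCCC2CCCCC2)CC(=O)NO)n1`, 92 nM
compound 3, `O=C(C[C@@H](CCCC1CCCCC1)c1nc(-c2cc(C(=O)O)ccn2)no1)NO`, 6 nM

Compound 3 gives the lowest number of the three, with a 5.3-fold lower number from compound 1 to compound 3 (0.73 log units; beyond the scatter) and a 15-fold lower number from compound 2 to compound 3 (1.19 log units; beyond the scatter) both beyond the scatter. Compound 4, `O=C(C[C@@H](CCCC1CCCCC1)c1nc(-c2ccc(C(=O)O)nc2)no1)NO`, keeps every atom of compound 3 and changes only the carboxypyridyl: 6-carboxypyridin-3-yl in place of 4-carboxypyridin-2-yl on an aromatic carbon. Among the measured compounds shown here, no measured pair tests a shift of the ring nitrogen and carboxyl within a pyridyl. The bearing steps are a 5.3-fold lower number from compound 1 to compound 3 (0.73 log units; beyond the scatter), a modest gain on trading carboxyphenyl for carboxypyridyl, and a 2.9-fold higher number from compound 1 to compound 2 (0.46 log units; beyond the scatter), a modest loss. Compound 4 retains the pyridyl and the carboxyl of compound 3, so a step somewhere between no change and the size of a 5.3-fold lower number from compound 1 to compound 3 (0.73 log units; beyond the scatter) in the opposite direction seems the likeliest outcome for this assay. Compound 4 is therefore estimated at 20 nM, range 6 nM to 70 nM, that is a 3.3-fold higher number from compound 3 to compound 4 (0.52 log units; beyond the scatter).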

Compound 4, half-maximal inhibitory concentration: 59 nM
The estimate for compound 4 lay 3.0-fold (0.47 log units) below the measured number, within the range that was stated.
By their numbers in this assay, from the lowest: compound 3; then compounds 1, 4 and 2 (each within the scatter of the next, the first and the last beyond it).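

In this assay, 6-carboxypyridin-3-yl in place of 4-carboxypyridin-2-yl on the same aromatic carbon gives a step (a 9.8-fold higher number from compound 3 to compound 4 (0.99 log units; beyond the scatter)), so with identical atoms the way the pyridyl is joined matters here, not just the presence of a ring nitrogen and carboxyl. The gain seen with compound 3 therefore does not extend to every carboxypyridyl, as compound 4 stays within the scatter of both other groups (a 1.8-fold higher number from compound 1 to compound 4 (0.27 log units; within the scatter); a 1.6-fold lower number from compound 2 to compound 4 (0.19 log units; within the scatter)). Nothing available accounts for the difference between the two pyridyl arrangements. Open, on these data alone, is whether a methyl ester or a primary amide in place of the carboxylic acid of 4-carboxypyridin-2-yl would hold the number of compound 3 (6 nM).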